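Hydroxymethyl replacing trifluoromethyl: cytotoxicity notes

The source may report more compounds than this note shows. Statements on the series, on what has been measured and on what is new or still open speak of the compounds shown alone.

Compound 1 `Cc1cc(/C=C/C#N)cc(C)c1Oc1cc(Nc2ccc(C#N)cc2)c(N)cc1[N+](=O)[O-]`: > 24400 nM (a limit)
Compound 2 `Cc1cc(/C=C/C#N)cc(C)c1Oc1cc(Nc2ccc(C#N)cc2)c(N)cc1C(F)(F)F`: 15000 nM

For the measured compounds named here, in an ADME assay on TZM cells (Homo sapiens) for cytotoxicity, read by XTT assay, with a stated time of 4 days (on this read-out lower numbers stand for higher toxicity in this test and higher numbers for lower toxicity in this test), compound 2 gives 15000 nM, the only exact number so far. The value of compound 1 is a limit of the assay, > 24400 nM.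

Compound 3 `Cc1cc(/C=C/C#N)cc(C)c1Oc1cc(Nc2ccc(C#N)cc2)c(N)cc1CO` has hydroxymethyl in place of trifluoromethyl on an aromatic carbon.

Going by the values given here, only one measured step bears on this carbon, an at least 1.6-fold lower number from compound 1 to compound 2 (0.21 log units; that floor lies within the scatter), and it is bounded by a floor, not sized exactly. No shift beyond the scatter is therefore expected in this assay, and the expected step is a 1.2-fold higher number from compound 2 to compound 3 (0.08 log units; within the scatter). For compound 3 the estimate is 18000 nM, with an expected range of 8000 nM to 32000 nM.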

Compound 3, half-maximal cytotoxic concentration: 16300 nM
Compound 3: middle estimate off by 1.1-fold (0.04 log units), on the high side, and the stated range covers the measured number.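

In this assay, for the compounds shown here, hydroxymethyl in place of trifluoromethyl gives the only exactly sized step on this carbon: a 1.1-fold higher number from compound 2 to compound 3 (0.04 log units; within the scatter). A hydrogen-bond donor and acceptor thus enter here, where trifluoromethyl has none, with no change in the read-out beyond the scatter. Against the nitro compound, the step is only a floor, an at least 1.4-fold lower number from compound 1 to compound 3 (0.17 log units; that floor lies within the scatter), and the value of compound 1 remains a limit: the limit of > 24400 nM in this assay, at which 1 of the 3 values shown sits.

Going by these compounds, whether an amine, a carboxylic acid or a longer chain on this carbon would shift the number beyond the scatter stays open. On these data alone, the true size of the step from nitro also stays open.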